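Swapping the ortho group on the aryl piperazine

The compounds below may be only part of what the source reports. "The series", "measured", "known", "first", "only" and "open" are said of these compounds alone.

Measured compounds:
compound 1, `COC(=O)C1=C(C)N=C(C)/C(=C(/O)OC)C1c1cccc(N/C(=N/CCNC2CCN(c3ccccc3[N+](=O)[O-])CC2)NC#N)c1`, 4 nM
compound 2, `COC(=O)C1=C(C)N=C(C)/C(=C(/O)OC)C1c1cccc(N/C(=N/CCNC2CCN(c3ccccc3C(F)(F)F)CC2)NC#N)c1`, 14 nM

In an assay on SK-N-MC cells for inhibition of Neuropeptide Y receptor type 1 (Homo sapiens) (a higher number here means a weaker inhibitor, a lower number a stronger inhibitor), compound 1 gives 4 nM. Compound 2 differs only at one aromatic carbon, where a trifluoromethyl stands in place of the nitro, and in this assay compound 2 gives 14 nM. Within the data shown here, of the two numbers available, compound 2 holds the higher one; the only step between them, a 3.5-fold higher number from compound 1 to compound 2 (0.54 log units; beyond the scatter), is modest but lies beyond the scatter.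

Compound 3, `COC(=O)C1=C(C)N=C(C)/C(=C(/O)OC)C1c1cccc(N/C(=N/CCNC2CCN(c3ccccc3OC)CC2)NC#N)c1`, carries the change (methoxy in place of trifluoromethyl on an aromatic carbon). Among the measured compounds shown here, no measured pair shows this particular swap, so the single comparison that bears on it is a 3.5-fold higher number from compound 1 to compound 2 (0.54 log units; beyond the scatter): a different group at the same position moved the number by a modest amount. A second exchange at this position is therefore expected to shift the number again by a modest amount, in either direction, and not by more than that. The estimate for compound 3 in this assay is 10 nM, with a range from 3 nM to 35 nM, which corresponds to an expected step of a 1.4-fold lower number from compound 2 to compound 3 (0.15 log units; within the scatter).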

Compound 3, half-maximal inhibitory concentration: 4 nM
The estimate for compound 3 lay 2.5-fold (0.40 log units) above the measured number; the measured number falls inside the stated range.
By their numbers in this assay, from the lowest: compounds 1 and 3 (each within the scatter of the next); then compound 2.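

In this assay methoxy gives a 3.5-fold lower number from compound 2 to compound 3 (0.54 log units; beyond the scatter) and so reverses a shift of the same size seen earlier, which means the loss seen with trifluoromethyl is not the price of replacing nitro with just any group. The comparison with the nitro compound reads no change at the digits printed from compound 1 to compound 3 (within the scatter) and shows that two different groups, nitro and methoxy, can give the same result at this place on the aromatic ring, leaving trifluoromethyl as the only one of the three that stands apart. From the compounds shown here alone, no other kind of measurement accompanies these numbers, so what sets trifluoromethyl apart stays unknown.

Nitro and methoxy both contain oxygen and trifluoromethyl does not, but three compounds cannot show whether that matters. An amine, a carboxylic acid or a longer chain such as ethoxy at this place would show how wide the range of accepted groups is, and the compounds shown say nothing about these groups elsewhere on the aromatic ring.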